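Adding a bromo group to compound 1

The source may report more compounds than this note shows. Statements on the series, on what has been measured and on what is new or still open speak of the compounds shown alone.

Among the compounds with values here, in a functional assay on SW-620 cells (Homo sapiens) (on this read-out lower numbers stand for stronger inhibition of growth and higher numbers for weaker inhibition of growth), compound 1 `O=S(=O)(/C=C/c1ccc(Cl)cc1Cl)Cc1ccc(Nc2ncnc3ccccc23)cc1` gives 14000 nM, the lowest of the three numbers measured so far and so the strongest growth inhibition in this small set. Compound 2 `O=S(=O)(/C=C/c1ccc(F)cc1Cl)Cc1ccc(Nc2ncnc3ccccc23)cc1` gives 100000 nM, and compound 3 `O=S(=O)(/C=C/c1ccc(O)cc1)Cc1ccc(Nc2ncnc3ccccc23)cc1` gives 100000 nM. Putting fluoro in place of one chloro weakened inhibition modestly, with a 7.1-fold higher number from compound 1 to compound 2 (0.85 log units; beyond the scatter). Putting 4-hydroxyphenyl in place of 2,4-dichlorophenyl gave a step of the same size, with a 7.1-fold higher number from compound 1 to compound 3 (0.85 log units; beyond the scatter). The remaining comparison shows no change at the digits printed from compound 2 to compound 3 (within the scatter).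

Compound 4 `O=S(=O)(/C=C/c1ccc(Cl)cc1Cl)Cc1ccc(Nc2ncnc3ccc(Br)cc23)cc1` keeps the 2,4-dichlorophenyl group of compound 1 and changes the shared core instead: bromo in place of hydrogen on an aromatic carbon. Within the data shown here, no measured compound carries a change at that place, so the data give no direction for this step. The measured steps, such as a 7.1-fold higher number from compound 1 to compound 2 (0.85 log units; beyond the scatter), show only how far a single change elsewhere in the molecule has moved this assay. The expected result is therefore no shift beyond the scatter, estimated as a 1.2-fold lower number from compound 1 to compound 4 (0.07 log units; within the scatter), although a modest move either way remains possible. For compound 4 the estimated value is 12000 nM, with an expected range from 3500 nM to 50000 nM.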

Compound 4, concentration for 50% growth inhibition: > 100000 nM
Compound 4: a limit, no number; the forecaster's own chance of this, stated with the estimate: 15%; at least 8.3-fold (0.92 log units) between middle value and limit.
By their numbers in this assay, from the lowest: compound 1; then compounds 2 and 3 (each within the scatter of the next).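

In this assay, bromo in place of hydrogen on an aromatic carbon of the shared core gives an at least 7.1-fold higher number from compound 1 to compound 4 (0.85 log units; beyond the scatter), even though the 2,4-dichlorophenyl group of compound 1 stays in place. Within the data shown here, until now, every measured step had come from changes at the other end of the molecule, so this is the first sign that the core also responds to a change, and that one bromine, a single heavy atom, is enough for a step beyond the scatter. The value of compound 4 is a limit of the assay and not a number, so the true size of this step remains unknown: the limit of > 100000 nM in this assay, at which 1 of the 4 values shown sits.

Only bromo is shown at this place, so it remains open whether an amine or a methoxy group there would keep the number close to that of compound 1. On these data alone, it is also open whether bromo at this place would move the numbers of compound 2 and compound 3 at all, and whether a bromo group on another carbon of the same ring would behave in the same way.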